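The compounds below may be only part of what the source reports. "The series", "measured", "known", "first", "only" and "open" are said of these compounds alone.

In an ADME assay, in phosphate buffer, at 28 degrees C, at pH 7.0 (a higher number here means that the compound lasts longer, a lower number that the compound disappears faster), compound 2, whose structure is `CC(C)(C)C1=C(C(=O)O)N2C(=O)[C@H](CO)[C@@H]2O1`, gives 2.4 h. Compound 1, with the structure `C[C@@H](O)[C@H]1C(=O)N2C(C(=O)O)=C(C(C)(C)C)O[C@H]12`, gives 8.1 h in this assay. For the measured compounds named here, that places compound 2 at the lower of the two numbers known, with compound 1 standing beyond the usual scatter above it. The unmeasured compound 3 has the structure `C[C@@H](O)[C@H]1C(=O)N2C(C(=O)O)=C(C(C)(C)C)O[C@@H]12`. Compared with compound 2 it carries methyl in place of hydrogen on a saturated chain carbon bound to an oxygen on a saturated carbon and a saturated ring carbon, so that the hydroxymethyl group becomes a 1-hydroxyethyl group, the same side chain that compound 1 bears on its core. Going by the values given here, no measured pair isolates this single change, so its effect on the half-life is not known from the data. Since compound 1, which carries the 1-hydroxyethyl group, gives 8.1 h, the step is expected to be a 2.5-fold higher number from compound 2 to compound 3 (0.40 log units; beyond the scatter), towards a longer half-life. For compound 3 the estimated half-life is 6 h, with a range from 2.5 h to 13 h.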

Compound 3, half-life: 6.4 h
Compound 3: middle estimate off by 1.1-fold (0.03 log units), on the low side, and the stated range covers the measured number.
By their numbers in this assay, from the lowest: compound 2; then compounds 3 and 1 (each within the scatter of the next).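

In this assay, for the compounds shown here, a single change at this side chain can now be read for the first time: methyl in place of hydrogen, which turns hydroxymethyl into 1-hydroxyethyl, gives a 2.7-fold higher number from compound 2 to compound 3 (0.43 log units; beyond the scatter), a modest step beyond the scatter. The change at the saturated ring carbon can also be read on its own, and a 1.3-fold lower number from compound 1 to compound 3 (0.10 log units; within the scatter) stays within the scatter, so in this pair the drawn configuration at that carbon gives no readable difference in half-life. This reading rests on one pair, and what makes that pair a clean comparison is: the fact that compounds 1 and 3 differ only in the configuration as drawn

The compounds shown leave open whether a longer chain on the same carbon, or an amine in place of the hydroxyl, would shift the half-life further. Also open, from the compounds shown here alone, is whether the methyl step would be the same with the ring carbon in the other configuration.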